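Benzimidazole in place of an aminophenyl imine on a coumarin

The compounds below may be only part of what the source reports. "The series", "measured", "known", "first", "only" and "open" are said of these compounds alone.

Measured compounds:
- compound 1, `Nc1ccccc1/N=C\c1cc(=O)oc2cc(OCc3ccccc3)ccc12`, 217000 nM in a functional assay, read by spectrophotometry, with a stated time of 5 min; on this read-out higher numbers stand for weaker inhibition and lower numbers for stronger inhibition
- compound 2, `O=c1cc(/C=N\O)c2c(OCc3ccccc3)cc(OCc3ccccc3)cc2o1`, > 2000000 nM in this assay
- compound 3, `Nc1ccccc1/N=C\c1cc(=O)oc2cc(OCc3ccccc3)cc(OCc3ccccc3)c12`, 258000 nM in this assay

The value of compound 2 in this assay is a limit of the assay and not a number.

Compound 1 and compound 3 sit close together in this assay; the step of a 1.2-fold higher number from compound 1 to compound 3 (0.08 log units; within the scatter) lies within the scatter. The step of an at least 7.7-fold lower number from compound 2 to compound 3 (0.88 log units; beyond the scatter) is the only one beyond the scatter among the shown compounds, and it concerns the group on the double-bonded nitrogen.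

Compound 4, `O=c1cc(-c2nc3ccccc3[nH]2)c2ccc(OCc3ccccc3)cc2o1`, differs from compound 1 in one place: a group of 9 heavy atoms (7 carbon, 2 nitrogen; one five-membered aromatic ring with 2 hetero atoms, one six-membered aromatic ring of carbon only) in place of a group of 9 heavy atoms (7 carbon, 2 nitrogen; one six-membered aromatic ring of carbon only), on an aromatic carbon. Neither measured step covers this change: the step from compound 2 to compound 3 exchanges the group on the nitrogen but keeps the open imine, and the step from compound 1 to compound 3 touches only a ring substituent. The data therefore give no direction for closing the imine into the benzimidazole ring, and the expectation is a step of a 1.1-fold lower number from compound 1 to compound 4 (0.04 log units; within the scatter), that is none beyond the scatter, with a wide range. Compound 4 is estimated at 200000 nM in this assay, expected between 50000 nM and 1000000 nM.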

Compound 4, half-maximal inhibitory concentration: 146000 nM
Compound 4: middle estimate off by 1.4-fold (0.14 log units), on the high side; the measured number falls inside the stated range.
By their numbers in this assay, from the lowest: compounds 4, 1 and 3 (each within the scatter of the next). At a limit, above all of these: compound 2.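

In this assay the 1H-benzimidazol-2-yl group in place of the open aminophenyl imine gives a 1.5-fold lower number from compound 1 to compound 4 (0.17 log units; within the scatter) at the aromatic carbon opposite the ring oxygen. The earlier steps shown here changed only a ring substituent or the group on the double-bonded nitrogen, whereas this one replaces the whole imine, and the number stays within the scatter even though the double bond outside aromatic rings is gone. Nothing measured here accounts for this result.

From the compounds shown here alone, it remains open whether the 1H-benzimidazol-2-yl group would give a similar number alongside the second benzyloxy group of compound 3. Going by these compounds, it is also open whether a methyl group or a carboxylic acid on the benzimidazole, or a simple amine at this position, would move the number beyond the scatter.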